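A few compounds are considered here, and "the series" means these few. Any claim that something is new, unique, unknown or untested is made for them only; others in the source may bear on it.

Compound 1 `CC/C=C/C(=O)Nc1cccc(Oc2nc(Nc3cccc(OC)c3)nc3c2CSCC3)c1`: 24200 nM
Compound 2 `C=CC(=O)Nc1cccc(Oc2nc(Nc3ccc(OC)cc3)nc3c2CSCC3)c1`: 11700 nM
Compound 3 `C/C=C/C(=O)Nc1cccc(Oc2nc(Nc3ccc(OC)cc3)nc3c2CSCC3)c1`: 24300 nM

All three values come from a functional assay on MCF7 cells (Homo sapiens) for antiproliferative activity, read by MTT assay, with a stated time of 72 h; on this read-out lower numbers stand for stronger inhibition and higher numbers for weaker inhibition. The number for compound 3 lies within the scatter of compound 1 and above that of compound 2. Moving on to compound 4 `CC/C=C/C(=O)Nc1cccc(Oc2nc(Nc3ccc(OC)cc3)nc3c2CSCC3)c1` makes a single change: methyl in place of hydrogen on a saturated chain carbon bound to a double-bonded chain carbon. Methyl replaces hydrogen on a saturated chain carbon bound to a double-bonded chain carbon, turning prop-1-en-1-yl into but-1-en-1-yl.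

The closest measured change is a 2.1-fold higher number from compound 2 to compound 3 (0.32 log units; beyond the scatter). It also extends this chain, and it was modest. Though it differs from compound 4 elsewhere, compound 1 already carries but-1-en-1-yl and gives 24200 nM, within the scatter of compound 3 at 24300 nM. Together these two observations suggest little further movement in this assay. The expected change, a 1.0-fold higher number from compound 3 to compound 4 (0.01 log units; within the scatter), is therefore none beyond the scatter. For compound 4 the estimated value is 25000 nM, with an expected range from 13000 nM to 48000 nM.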

Compound 4, half-maximal inhibitory concentration: 31400 nM
The estimate for compound 4 lay 1.3-fold (0.10 log units) below the measured number; measured number inside the range.
By their numbers in this assay, from the lowest: compound 2; then compounds 1, 3 and 4 (each within the scatter of the next).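

Turning prop-1-en-1-yl into but-1-en-1-yl leaves the number in this assay within the scatter, at a 1.3-fold higher number from compound 3 to compound 4 (0.11 log units; within the scatter), so this added methyl on the saturated chain carbon has no measurable effect. The larger change from vinyl to but-1-en-1-yl, a 2.7-fold higher number from compound 2 to compound 4 (0.43 log units; beyond the scatter), lies beyond the scatter, while 4-methoxyphenyl in place of 3-methoxyphenyl, a 1.3-fold higher number from compound 1 to compound 4 (0.11 log units; within the scatter), stays within it, so among these compounds only compound 2 stands apart. No measurement at hand explains these numbers.

Going by these compounds, it remains open whether a longer chain, or an amine at the end of this chain, would also stay within the scatter of compound 4. On these data alone, it is also open whether the methoxy shift would matter with vinyl on the carbonyl carbon.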